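Cytotoxicity notes on a shared-core series

The source may report more compounds than this note shows. Statements on the series, on what has been measured and on what is new or still open speak of the compounds shown alone.

Values in an ADME assay on HFF cells (Homo sapiens) for cytotoxicity, read by MTT assay, with a stated time of 72 h; on this read-out lower numbers stand for stronger inhibition and higher numbers for weaker inhibition:
Compound 1 `CC(C)(C)c1cn(C[C@H](O)[C@H]2OC(=O)C(OCc3ccccc3)=C2OCc2ccccc2)nn1` gives 13300 nM.
Compound 2 `O=C1O[C@H]([C@@H](O)Cn2cc(C3CC3)nn2)C(OCc2ccccc2)=C1OCc1ccccc1` gives 24300 nM.

Among the compounds with values here, compound 2 stands within the scatter of compound 1, the only other number, the step being a 1.8-fold higher number from compound 1 to compound 2 (0.26 log units; within the scatter). Compound 3 `O=C1O[C@H]([C@@H](O)Cn2cc(CNS(=O)(=O)c3ccc(Cl)cc3)nn2)C(OCc2ccccc2)=C1OCc1ccccc1` carries (((4-chlorophenyl)sulfonyl)amino)methyl in place of cyclopropyl on an aromatic carbon. Within the data shown here, no measured step exchanges a small carbon ring for a group of this kind; the single step on record concerns a different exchange and stays within the scatter, so it gives no ground to expect a shift in this assay beyond the scatter in either direction. Compound 3 is therefore expected near 20000 nM, range 7000 nM to 60000 nM, an expected step of a 1.2-fold lower number from compound 2 to compound 3 (0.08 log units; within the scatter).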

Compound 3, half-maximal inhibitory concentration: 20 nM
Compound 3: the middle estimate sits 1000-fold (3.00 log units) above what was measured; measured number outside the range, below it.
By their numbers in this assay, from the lowest: compound 3; then compounds 1 and 2 (each within the scatter of the next).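

On this aromatic carbon of the five-membered ring, (((4-chlorophenyl)sulfonyl)amino)methyl gives a 1200-fold lower number from compound 2 to compound 3 (3.08 log units; beyond the scatter) and a 670-fold lower number from compound 1 to compound 3 (2.82 log units; beyond the scatter) in this assay. The tert-butyl and cyclopropyl pair stayed within the scatter, so the position's capacity to move this read-out appears only with this entering group. No available measurement accounts for a step of this size.

Which part of the entering group carries the step remains open: the chlorine, the phenyl ring or the sulfonyl amino link. A plain aminomethyl, a carboxylic acid or a longer carbon chain at this carbon would help separate these parts.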